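The source may hold more compounds than are shown below. What is called first, only, known or untested is meant among the compounds shown, and "the series" means these compounds.

Measured so far in a functional assay on SK-BR-3 cells (Homo sapiens) for antiproliferative activity, read by MTT assay, with a stated time of 72 h; on this read-out lower numbers stand for stronger inhibition and higher numbers for weaker inhibition: compound 1 `CCN1CCN(c2cc(C)c3cc(NC(=O)c4ccccc4F)ccc3n2)CC1` with 38100 nM; compound 2 `CCN(CC)CCNc1cc(C)c2cc(NC(=O)c3ccc(Cl)c(Cl)c3)ccc2n1` with 3710 nM; compound 3 `CCN1CCN(c2cc(C)c3cc(NC(=O)c4cccnc4)ccc3n2)CC1` with 10600 nM.

Compound 2 gives the lowest of the three numbers, with compound 3 nearest and compound 1 furthest. For the measured compounds named here, the only measured step between compounds differing in one place is a 3.6-fold lower number from compound 1 to compound 3 (0.56 log units; beyond the scatter), and it concerns the group on the carbonyl carbon, not the chain altered here. Going by the values given here, no measured step therefore bears directly on the move to compound 4 `CCNc1cc(C)c2cc(NC(=O)c3ccc(Cl)c(Cl)c3)ccc2n1`. That move is hydrogen in place of diethylamino on a saturated chain carbon, two bonds along the chain from a nitrogen on an aromatic ring. With nothing comparable to lean on, only a cautious guess is possible, and the number for compound 4 is expected to rise, a 3.0-fold higher number from compound 2 to compound 4 (0.47 log units; beyond the scatter). Compound 4 is thus estimated at 11000 nM, within 3000 nM to 40000 nM.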

Compound 4, half-maximal inhibitory concentration: 28200 nM
Compound 4: middle estimate off by 2.6-fold (0.41 log units), on the low side, within the range that was stated.
By their numbers in this assay, from the lowest: compound 2; then compound 3; then compounds 4 and 1 (each within the scatter of the next).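

Swapping (2-(diethylamino)ethyl)amino for ethylamino gives a 7.6-fold higher number from compound 2 to compound 4 (0.88 log units; beyond the scatter) in this assay. For the compounds shown here, this is the first measured sign that the diethylamino end of the chain matters on this read-out, since losing it weakens inhibition beyond the usual scatter. No measurement at hand explains the rise, and it cannot be told whether the nitrogen or the carbons that leave with it account for the change.

As far as these compounds go, it remains open whether dimethylamino, a ring amine such as pyrrolidine or a longer chain carrying diethylamino would keep or lower the number of compound 2.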